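Mirror image of the most rapidly cleared compound

The source may hold more compounds than are shown below. What is called first, only, known or untested is meant among the compounds shown, and "the series" means these compounds.

In an ADME assay on the whole organism (Rattus norvegicus, strain Wistar Han) for pharmacokinetics, at a dose of 0.05 mg/kg by the intravenous route (a lower number here means slower removal, a higher number faster removal of the compound), compound 1 (`O=C(NC1(c2ccc3c(n2)CCN3C(=O)OC2CC2)CC1)c1ccc(Cl)cc1`) gives 174 mL/min/kg, compound 3 (`O=C(C1CC1)N1CCc2nc(C3(C(=O)Nc4ccc(F)cc4)CCC3)ccc21`) gives 668 mL/min/kg, and compound 2 (`COC(=O)N1c2ccc(C3(NC(=O)c4ccc(F)cc4)CC3)cc2[C@@H]2CC[C@@H]21`) gives 2900 mL/min/kg. Compound 2 therefore stands highest of the three, and the other two lie below it by more than the usual scatter. Compound 4 (`COC(=O)N1c2ccc(C3(NC(=O)c4ccc(F)cc4)CC3)cc2[C@H]2CC[C@H]21`) has yet to be measured in this assay. Going from compound 2 to compound 4, the change is the two compounds have the same atoms and bonds and differ only in configuration as drawn: 2 of 2 stereo elements differ (all stereocentres are inverted: mirror images); a stereocentre at a saturated ring carbon is drawn S in compound 2 and R in compound 4; a stereocentre at a saturated ring carbon is drawn S in compound 2 and R in compound 4: the two compounds have the same atoms and bonds, and all stereocentres are inverted, making them mirror images. Going by the values given here, no measured pair in this set shows what such an inversion does to the read-out, so the expectation is cautious. Compound 2, at 2900 mL/min/kg, tops a small set, which suggests only a slight drift downward. The expected change is a 1.5-fold lower number from compound 2 to compound 4 (0.16 log units; within the scatter), which would stay within the scatter. Compound 4 is estimated at 2000 mL/min/kg, with an expected range from 800 mL/min/kg to 4500 mL/min/kg.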

Compound 4, clearance: 2320 mL/min/kg
Compound 4: the middle estimate sits 1.2-fold (0.06 log units) below what was measured, and the stated range covers the measured number.
By their numbers in this assay, from the lowest: compound 1; then compound 3; then compounds 4 and 2 (each within the scatter of the next).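

Compounds 2 and 4 give the set its first comparison in which a single feature alone is altered: the fact that compounds 2 and 4 differ only in the configuration as drawn

In this assay, inverting both stereocentres at the saturated ring carbons gives a 1.3-fold lower number from compound 2 to compound 4 (0.10 log units; within the scatter), so the two mirror images cannot be told apart on this read-out. The rapid removal seen for compound 2 is thus not peculiar to one configuration at this position: compound 4 gives 2320 mL/min/kg.

As far as these compounds go, what inverting only one of the two stereocentres would do remains open. Also open, from the compounds shown here alone, is whether an amine or a carboxylic acid at a saturated ring carbon would leave the two configurations as close as they are here.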